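Swapping the trifluoromethyl for fluoro on compound 3

The compounds below may be only part of what the source reports. "The series", "measured", "known", "first", "only" and "open" are said of these compounds alone.

Of the compounds shown here, three share one core and have been measured in an ADME assay on HepG2 cells (Homo sapiens), read by MTT assay, with a stated time of 72 h, in the presence of a further agent that is not named here; on this read-out higher numbers stand for weaker inhibition and lower numbers for stronger inhibition. Compound 1 `O=C(Nc1ccccc1)Oc1ccc(Cl)cc1C(=O)Nc1ccc(F)cc1` gives 3250 nM. Compound 2 `O=C(NCc1ccccc1)Oc1ccc(Cl)cc1C(=O)Nc1ccc(C(F)(F)F)cc1` gives 3000 nM. Compound 3 `O=C(NC1CCCCC1)Oc1ccc(Cl)cc1C(=O)Nc1ccc(C(F)(F)F)cc1` gives 750 nM, the lowest of the three numbers, and its step to each of the others is beyond the scatter. For the measured compounds named here, the one step that can be read cleanly is a 4.0-fold lower number from compound 2 to compound 3 (0.60 log units; beyond the scatter), where cyclohexyl replaces benzyl on an amide-type nitrogen.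

Compound 4 `O=C(NC1CCCCC1)Oc1ccc(Cl)cc1C(=O)Nc1ccc(F)cc1` keeps the cyclohexyl of compound 3 and differs from it only as follows: fluoro in place of trifluoromethyl on an aromatic carbon. Going by the values given here, no measured pair differs by this change alone; compound 1 and compound 2 carry fluoro and trifluoromethyl but also differ in the group on the amide-type nitrogen, so their two values show only that they lie close together. Among the compounds with values here, with no step bearing directly on this change, the expected step is a 2.0-fold higher number from compound 3 to compound 4 (0.30 log units; within the scatter), small and uncertain in direction. Compound 4 is therefore estimated at 1500 nM, with a range from 500 nM to 4500 nM.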

Compound 4, half-maximal inhibitory concentration: 8600 nM
Beside the measured number, compound 4's estimate is 5.7-fold (0.76 log units) below it; measured number above the stated range.
By their numbers in this assay, from the lowest: compound 3; then compounds 2 and 1 (each within the scatter of the next); then compound 4.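

In this assay, for the compounds shown here, the change from 4-(trifluoromethyl)phenyl to 4-fluorophenyl gives an 11-fold higher number from compound 3 to compound 4 (1.06 log units; beyond the scatter) and is the first clean reading at this position, showing that the group on this aromatic carbon counts for much when cyclohexyl sits on the amide-type nitrogen. Cyclohexyl does not lower the number in every setting: with fluoro on the ring, its replacement of phenyl gives a 2.6-fold higher number from compound 1 to compound 4 (0.42 log units; beyond the scatter) and so raises the number, unlike its replacement of benzyl in the trifluoromethyl pair, a 4.0-fold lower number from compound 2 to compound 3 (0.60 log units; beyond the scatter). Nothing measured here accounts for either result.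

Going by these compounds, whether trifluoromethyl has as large an effect with phenyl or benzyl on that nitrogen stays open. So does the outcome of a nitrile or methoxy group on this same aromatic carbon.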